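Swapping the five-membered ring on a sulfoxide dopamine transporter series

The compounds below may be only part of what the source reports. "The series", "measured", "known", "first", "only" and "open" are said of these compounds alone.

Measured so far:
compound 1, `COC1NN=C(C[S+]([O-])C(c2ccccc2)c2ccccc2)S1`, 108000 nM
compound 2, `[O-][S+](Cc1ccc(Cl)s1)C(c1ccccc1)c1ccccc1`, 12800 nM
compound 3, `Cc1noc(C[S+]([O-])C(c2ccccc2)c2ccccc2)n1`, 56700 nM

Going by the values given here, all three share a core in which a diphenylmethyl sulfoxide carries a methylene linked to a five-membered ring; only that ring varies. In an assay on HEK293 cells for inhibition of sodium-dependent dopamine transporter (Homo sapiens), read by scintillation counting, with stated times of 5 min and 1 min (a higher number here means a weaker inhibitor, a lower number a stronger inhibitor), compound 3 sits second highest of the three numbers, close to compound 1 and set apart from compound 2. The step of a 1.9-fold lower number from compound 1 to compound 3 (0.28 log units; within the scatter) shows that exchanging the non-aromatic ring of compound 1 for the aromatic oxadiazole of compound 3 leaves the number essentially where it was, whereas the step of a 4.4-fold higher number from compound 2 to compound 3 (0.65 log units; beyond the scatter) shows a modest rise from the chlorothiophene of compound 2 to the oxadiazole of compound 3.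

Compound 4 is `Cc1nnc(C[S+]([O-])C(c2ccccc2)c2ccccc2)s1`. Its difference from compound 3 is 5-methyl-1,3,4-thiadiazol-2-yl in place of 3-methyl-1,2,4-oxadiazol-5-yl on a saturated chain carbon bound to a sulfur: a sulfur-containing aromatic ring takes the place of an oxygen-containing one, with the same ring size and the same count of hetero atoms. The two steps above bear on it only loosely; the sulfur-bearing aromatic ring of compound 2 gives the lowest number in this assay, so compound 4 is expected to move modestly in that direction, a 1.9-fold lower number from compound 3 to compound 4 (0.28 log units; within the scatter), though a change within the scatter would not surprise. Compound 4 is therefore estimated at 30000 nM, with a range from 10000 nM to 90000 nM.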

Compound 4, half-maximal inhibitory concentration: "not active" (no number reported)
Compound 4: no number reported, and the estimate cannot be compared.
By their numbers in this assay, from the lowest: compound 2; then compounds 3 and 1 (each within the scatter of the next).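

In this assay, going by these compounds alone, compound 4 is reported as not active, without a number, so no step from compound 3 to compound 4 can be read. The compounds shown leave open how 5-methyl-1,3,4-thiadiazol-2-yl compares numerically with 3-methyl-1,2,4-oxadiazol-5-yl. No supporting data bear on this result.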